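A Smaller Ring on the Sulfur: Compound 4

The source may hold more compounds than are shown below. What is called first, only, known or untested is meant among the compounds shown, and "the series" means these compounds.

Of the compounds shown here, three sharing one core have been measured in a functional assay on HT-29 cells (Homo sapiens) for cytotoxicity, read by MTT assay, with a stated time of 24 h, tested at 1.6 ug/mL; a lower number here means a weaker effect, a higher number a stronger effect of the compound at the concentration tested. Compound 1 `Cn1c(-c2ccc(NC(=O)CSc3nc4ccccc4o3)cc2)nc(-c2ccccc2)c1-c1ccccc1` gives 41%. Compound 2 `Cn1c(-c2ccc(NC(=O)CSc3nc4cc(Cl)ccc4o3)cc2)nc(-c2ccccc2)c1-c1ccccc1` gives 17.4% in this assay, and compound 3 `Cn1c(-c2ccc(NC(=O)CSc3nc4ccccc4s3)cc2)nc(-c2ccccc2)c1-c1ccccc1` gives 15.3%. Compound 3 holds the lowest of the three numbers; its gap to compound 2 lies within the scatter, while the step of a number 25.7 percentage points lower from compound 1 to compound 3 (beyond the scatter) lies beyond it. Compound 4 `Cn1ccnc1SCC(=O)Nc1ccc(-c2nc(-c3ccccc3)c(-c3ccccc3)n2C)cc1` has not been measured. It differs from compound 3 in one place: 1-methyl-1H-imidazol-2-yl in place of 1,3-benzothiazol-2-yl on a sulfur. Of the measured steps, only a number 25.7 percentage points lower from compound 1 to compound 3 (beyond the scatter) changed the group on the sulfur, and a number 2.1 percentage points lower from compound 2 to compound 3 (within the scatter) compared two such groups without a shift beyond the scatter. Among the measured compounds shown here, neither step put a single five-membered ring on the sulfur, so no measured step covers this change directly. The expectation therefore stays near compound 3, and the expected step of a number 6.7 percentage points higher from compound 3 to compound 4 (within the scatter) is small, with wide uncertainty in both directions. Compound 4 is estimated at 22%, between 5% and 48%.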

Compound 4, a percentage reported as activity, at one concentration (the size of the read-out at that concentration, not a potency): 23.8%
For compound 4 the middle estimate is 1.8 percentage points below the measured one; the range from low to high includes it.
By their numbers in this assay, from the lowest: compounds 3, 2 and 4 (each within the scatter of the next); then compound 1.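

In this assay, the step of a number 8.5 percentage points higher from compound 3 to compound 4 (within the scatter) and the step of a number 6.4 percentage points higher from compound 2 to compound 4 (within the scatter) show that a single ring on the sulfur, 1-methyl-1H-imidazol-2-yl, gives a number that cannot be told apart from those of two fused groups. The step of a number 17.2 percentage points lower from compound 1 to compound 4 (beyond the scatter) shows that the unsubstituted 1,3-benzoxazol-2-yl of compound 1 still stands apart from this smaller group. Having a six-membered carbon ring in the group therefore does not by itself set the number among these compounds, since compound 1, compound 2 and compound 3 all carry one, and no other kind of data here bears on these differences.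

The compounds shown leave open what happens when the methyl on the imidazole is replaced by hydrogen. They also do not show whether an open chain carrying an amine or a carboxylic acid could take the place of the ring on the sulfur.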